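The source may report more compounds than this note shows. Statements on the series, on what has been measured and on what is new or still open speak of the compounds shown alone.

Compounds measured in a functional assay on KB cells (Homo sapiens) for antiproliferative activity, read by sulforhodamine B assay, with a stated time of 3 days; on this read-out higher numbers stand for an effect only at larger amounts of compound and lower numbers for an effect already at smaller amounts:

- Compound 1 `CCC1=C(O)c2c(oc(-c3ccccc3)cc2=O)C(CC)(CC)C1=O`: > 236 uM, a limit
- Compound 2 `CCCc1ccc(-c2cc(=O)c3c(o2)C(CC)(CC)C(=O)C(CC)=C3O)cc1`: > 53 uM, a limit
- Compound 3 `CCCCc1ccc(-c2cc(=O)c3c(o2)C(CC)(CC)C(=O)C(CC)=C3O)cc1`: 111 uM

Compound 1 has no exact number on this read-out, only the limit > 236 uM. Compound 4 `CCC1=C(O)c2c(oc(-c3ccc(CC(C)C)cc3)cc2=O)C(CC)(CC)C1=O` departs from it by one change, isobutyl in place of hydrogen on an aromatic carbon, para to a large group.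

The nearest measured change is butyl in place of hydrogen on an aromatic carbon, which gave an at least 2.1-fold lower number from compound 1 to compound 3 (0.32 log units; beyond the scatter). The other two measured steps add little. Propyl in place of hydrogen gave a step that the two limits leave unreadable from compound 1 to compound 2, and the added methyl on the chain gave a step that the limit leaves unreadable from compound 2 to compound 3. The expectation therefore rests on a single readable step. The starting point of that step is only a limit. The true size of the step is not known.

In this assay, a lower number than for compound 1 is expected, similar in size to the butyl step. The estimated step is an at least 2.2-fold lower number from compound 1 to compound 4 (0.35 log units; beyond the scatter). For compound 4 the estimated value is 105 uM, with an expected range from 50 uM to 230 uM.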

Compound 4, concentration for half-maximal effect: 29.3 uM
Beside the measured number, compound 4's estimate is 3.6-fold (0.55 log units) above it; measured number outside the range, below it.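

In this assay, for the compounds shown here, moving from a straight to a branched chain on this aromatic carbon gives a 3.8-fold lower number from compound 3 to compound 4 (0.58 log units; beyond the scatter), the first step here with exact numbers at both ends, and it shows that the shape of the chain matters and not only its presence. Isobutyl in place of hydrogen gives an at least 8.0-fold lower number from compound 1 to compound 4 (0.90 log units; beyond the scatter), and that size is only a floor, as compound 1 has no exact number but a limit: the limit of > 236 uM in this assay, at which 1 of the 4 values shown sits. The comparison with the propyl compound gives an at least 1.8-fold lower number from compound 2 to compound 4 (0.25 log units; that floor lies within the scatter), and it too is only a floor, as compound 2 also has just a limit: the limit of > 53 uM in this assay, at which 1 of the 4 values shown sits.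

Isobutyl is the only branched group shown at this position, so a single compound carries the effect of branching, and why it differs from butyl remains unexplained. Going by these compounds, whether a tert-butyl group or a longer chain such as hexyl would lower the number further stays open, as does the effect of an amine or a carboxylic acid on the same aromatic carbon.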